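The source may report more compounds than this note shows. Statements on the series, on what has been measured and on what is new or still open speak of the compounds shown alone.

In a functional assay on MCF7 cells (Homo sapiens) for cytotoxicity, read by MTT assay, with a stated time of 6 days (on this read-out lower numbers stand for an effect already at smaller amounts and higher numbers for an effect only at larger amounts of compound), compound 1 `COC(=O)c1c(-c2cc(OC)cc(OC)c2)oc2ccccc2c1=O` gives only a limit, > 25 ug/mL. Compound 3 `COc1cc(OC)cc(-c2oc3ccccc3c(=O)c2C(=O)O)c1` likewise reaches only a limit in this assay, > 25 ug/mL. The change from compound 1 to compound 3 is hydrogen in place of methyl on an oxygen next to a carbonyl group, and the step it made, a step that the two limits leave unreadable from compound 1 to compound 3, cannot be read because of the limit of > 25 ug/mL in this assay, at which 3 of the 3 values shown sit. Compound 2 `COC(=O)c1c(-c2ccc([N+](=O)[O-])cc2)oc2ccccc2c1=O` also gives only a limit in this assay, > 25 ug/mL. How the core of compound 2 differs from the core of compound 1 is not broken down here. Compound 4 `O=C(O)c1c(-c2ccc([N+](=O)[O-])cc2)oc2ccccc2c1=O` has not yet been measured in this assay. It differs from compound 2 by hydrogen in place of methyl on an oxygen next to a carbonyl group, the same change, at the same place, that leads from compound 1 to compound 3. Compound 2 sits at the limit with > 25 ug/mL, and the earlier step that the two limits leave unreadable from compound 1 to compound 3 gave no readable size, so nothing in the measured compounds points to a gain. The step is therefore expected to be a step that the limit leaves unreadable from compound 2 to compound 4. Compound 4 is estimated at 40 ug/mL, between 20 ug/mL and 120 ug/mL, and is expected most likely to give again only a limit in this assay.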

Compound 4, concentration for half-maximal effect: > 25 ug/mL
Compound 4 was reported as a limit; the forecaster's own chance of this, stated with the estimate: 80%; the middle value lies beyond the limit too.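

Compound 2 and compound 4 both give only a limit in this assay, so no size can be read for the change from methoxycarbonyl to carboxy between them: the limit of > 25 ug/mL in this assay, at which 4 of the 4 values shown sit.

The compounds shown leave open whether this change alters the effect on the cells at all, and how far each of the four compounds lies beyond the limit.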